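Another Group on the Core, Measured Against a Limit

This account rests on a few compounds, and the source may have more. Where it says the series, first, only, none or still open, it means among the compounds named here.

Compound 1 `O=c1oc(Nc2ccccc2I)nc2ccccc12`: in an assay on isolated protein for inhibition of complement C1r subcomponent (Homo sapiens) (a higher number here means a weaker inhibitor, a lower number a stronger inhibitor), compound 1 gives 3500 nM.
Compound 2 `COc1ccc2c(=O)oc(Nc3ccccc3I)nc2c1`: in this assay compound 2 gives > 62500 nM, a limit of the assay rather than a number.
Compound 3 `CC(C)c1ccc2c(=O)oc(Nc3ccccc3I)nc2c1`: in this assay compound 3 gives > 62500 nM, likewise only a limit.

Compound 3 therefore stands at the edge of what the assay can read, and one further value shown sits at that same edge (the limit of > 62500 nM in this assay, at which 2 of the 3 values shown sit). Compound 4 `O=c1oc(Nc2ccccc2I)nc2cc(C3CCCCC3)ccc12` differs from compound 3 in one place: cyclohexyl in place of isopropyl on an aromatic carbon. Within the data shown here, the steps that bear on this change are an at least 17-fold higher number from compound 1 to compound 2 (1.25 log units; beyond the scatter) and an at least 17-fold higher number from compound 1 to compound 3 (1.25 log units; beyond the scatter), both large losses on placing a group at this position, while a step that the two limits leave unreadable from compound 2 to compound 3. With a larger group entering at the same place, no recovery is expected; the expected step is a step that the limit leaves unreadable from compound 3 to compound 4. Compound 4 is estimated at 90000 nM, between 20000 nM and 400000 nM.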

Compound 4, half-maximal inhibitory concentration: > 62500 nM
Compound 4: a limit, no number; the forecaster's own chance of this, stated with the estimate: 75%; the middle value lies beyond the limit too.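

Cyclohexyl, a non-aromatic ring of carbon, also weakens inhibition at this position in this assay, giving an at least 17-fold higher number from compound 1 to compound 4 (1.25 log units; beyond the scatter). The large loss now holds for three different groups, methoxy, isopropyl and cyclohexyl, and none of the compounds shown goes against it. The steps among compound 2, compound 3 and compound 4 cannot be read, and these groups cannot be ranked, because all three compounds share one limit: the limit of > 62500 nM in this assay, at which 3 of the 4 values shown sit.

On these data alone, whether a fluorine atom or an amine at this position would keep the inhibition seen for compound 1 stays open.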